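Methoxy in Place of Methyl: Expecting Another Limit

The compounds below may be only part of what the source reports. "The series", "measured", "known", "first", "only" and "open" are said of these compounds alone.

Compound 1 `CCNC(=O)N1CCN(C(=S)SCc2cn(Cc3ccccc3F)nn2)CC1` gives in a functional assay on SMMC-7721 cells (Homo sapiens) for cytotoxicity, read by MTT assay, with a stated time of 72 h (on this read-out lower numbers stand for stronger inhibition and higher numbers for weaker inhibition), only a limit of the assay, > 128000 nM.
Compound 2 `CCNC(=O)N1CCN(C(=S)SCc2cn(Cc3ccc(Cl)cc3)nn2)CC1` gives in this assay only a limit, > 128000 nM.
Compound 3 `CCNC(=O)N1CCN(C(=S)SCc2cn(Cc3ccc(C)cc3)nn2)CC1` gives in this assay only a limit, > 128000 nM.

Compound 3 therefore stands nowhere in particular on these numbers: its value is a limit, not a measured number, and it sits at the limit of > 128000 nM in this assay, at which 3 of the 3 values shown sit. Compound 4 `CCNC(=O)N1CCN(C(=S)SCc2cn(Cc3ccc(OC)cc3)nn2)CC1` differs from compound 3 by methoxy in place of methyl on an aromatic carbon, para to a large group. Within the data shown here, no measured step bears on this exact change. The steps that exist, a step that the two limits leave unreadable from compound 1 to compound 2, a step that the two limits leave unreadable from compound 1 to compound 3 and a step that the two limits leave unreadable from compound 2 to compound 3, all have a size that cannot be read, since both ends of each are limits. No exchange of one group for another on that aromatic ring has so far produced a readable number in this assay, so the expectation for compound 4 is that the methoxy group changes nothing that can be seen: the expected step is a step that the limit leaves unreadable from compound 3 to compound 4, no direction beyond the scatter. Compound 4 is estimated at 160000 nM in this assay, with an expected range from 60000 nM to 400000 nM, most likely reported again as a limit.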

Compound 4, half-maximal inhibitory concentration: > 128000 nM
Compound 4 gave a limit, no number (the forecaster's own chance of this, stated with the estimate: 85%); the middle value is on the limit's open side.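

Compound 4 joins compound 1, compound 2 and compound 3 as a limit rather than a number, so none of its steps to them can be read in this assay, and all four compounds sit at the same edge: the limit of > 128000 nM in this assay, at which 4 of the 4 values shown sit.

What stays open is how strongly any of these compounds acts on the cells, and whether any group on that aromatic ring would give a readable number.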